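Swapping the Thiazole on the Sulfonamide for a Thiadiazole

The source may report more compounds than this note shows. Statements on the series, on what has been measured and on what is new or still open speak of the compounds shown alone.

Within the data shown here, compound 1 `Cn1nccc1[C@H]1CCCC[C@@H]1Oc1cc(F)c(S(=O)(=O)Nc2ccncn2)c(F)c1` and compound 2 `Cn1nccc1[C@H]1CCC[C@@H]1Oc1cc(F)c(S(=O)(=O)Nc2nccs2)cc1F` are built on the same general framework but differ at more than one place, so no single step links them. In an ADME assay for permeability, using PAMPA, with a stated time of 4 h, at pH 7.4, tested at 5 uM (a higher number here means that the compound crosses the layer faster, a lower number that the compound crosses the layer more slowly), compound 1 gives 2.2 10^-6 cm/s. Compound 2 reaches only a limit of this assay, > 50 10^-6 cm/s, which is not a number but the edge of what the assay reports; this is the limit of > 50 10^-6 cm/s in this assay, at which 1 of the 2 values shown sits. Compound 3 `Cc1nsc(NS(=O)(=O)c2cc(F)c(O[C@H]3CCC[C@@H]3c3ccnn3C)cc2F)n1` carries 3-methyl-1,2,4-thiadiazol-5-yl in place of 1,3-thiazol-2-yl on a sulfonamide nitrogen. Among the measured compounds shown here, no measured pair shows this change, so only a small step, if any, is expected from compound 2 to compound 3, an at least 1.2-fold lower number from compound 2 to compound 3 (0.09 log units; that floor lies within the scatter), toward slower crossing if anything. Compound 3 is therefore expected to give 40 10^-6 cm/s, between 12 10^-6 cm/s and 60 10^-6 cm/s.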

Compound 3, apparent permeability in the ADME assay: 12.6 10^-6 cm/s
Compound 3: middle estimate off by 3.2-fold (0.50 log units), on the high side; the range from low to high includes it.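

In the ADME assay, 3-methyl-1,2,4-thiadiazol-5-yl in place of 1,3-thiazol-2-yl on a sulfonamide nitrogen brings an at least 3.9-fold lower number from compound 2 to compound 3 (0.59 log units; beyond the scatter). Compound 2 reads only a limit in that assay, so this step is a floor. In a physicochemical assay for lipophilicity, read by LC-MS, in phosphate buffer, measured as octanol-water partition, with a stated time of 30 min, at pH 7.4 (on this read-out higher numbers stand for higher lipophilicity and lower numbers for lower lipophilicity), compound 2 gives 2.1 and compound 3 gives 0.9, so both read-outs fall together across this one change.

This single pair cannot separate the added methyl group from the change of ring. It leaves open how a 1,2,4-thiadiazol-5-yl without the methyl group, or a pyridine ring, would read on the same nitrogen.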